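Carbamate ester variation in the spiro series: compound 3

A few compounds are considered here, and "the series" means these few. Any claim that something is new, unique, unknown or untested is made for them only; others in the source may bear on it.

Among the compounds with values here, compound 2 `CC1(OC(=O)N2CCC3(CC2)CC(CCCOc2ccc(S(C)(=O)=O)c(F)c2)C3)CC1` holds the nominally highest of the two numbers so far: in a functional assay on cells for agonist activity at Glucose-dependent insulinotropic receptor (Homo sapiens), read by HTRF and cAMP accumulation, with a stated time of 30 min (on this read-out higher numbers stand for an effect only at larger amounts of compound and lower numbers for an effect already at smaller amounts), compound 2 gives 13 nM, and compound 1 `CC(C)(C)OC(=O)N1CCC2(CC1)CC(CCCOc1ccc(S(C)(=O)=O)c(F)c1)C2` gives 9 nM. The step of a 1.4-fold higher number from compound 1 to compound 2 (0.16 log units; within the scatter) is within the scatter, so the two compounds are not separated by this assay. Compound 3 `CS(=O)(=O)c1ccc(OCCCC2CC3(CCN(C(=O)OC4CCCC4)CC3)C2)cc1F` carries cyclopentyl in place of 1-methylcyclopropyl on an oxygen next to a carbonyl group. Within the data shown here, the only measured step that bears on this position is a 1.4-fold higher number from compound 1 to compound 2 (0.16 log units; within the scatter), which shows that exchanging one small saturated carbon group for another on the oxygen next to the carbonyl group did not move the number beyond the scatter. Compound 3 is therefore expected to sit close to compound 2 in this assay. The expected step is no change at the digits printed from compound 2 to compound 3 (within the scatter), with no direction beyond the scatter. Compound 3 is estimated at 13 nM, within a range of 5 nM to 35 nM.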

Compound 3, half-maximal effective concentration in the Glucose-dependent insulinotropic receptor assay: 23 nM
Estimate against measurement, compound 3: 1.8-fold (0.25 log units) below; the measured number falls inside the stated range.
By their numbers in the Glucose-dependent insulinotropic receptor assay, from the lowest: compounds 1, 2 and 3 (each within the scatter of the next, the first and the last beyond it).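

Within the data shown here, in the Glucose-dependent insulinotropic receptor assay, cyclopentyl in place of 1-methylcyclopropyl on the oxygen next to a carbonyl group gives a 1.8-fold higher number from compound 2 to compound 3 (0.25 log units; within the scatter), whereas cyclopentyl in place of tert-butyl gives a 2.6-fold higher number from compound 1 to compound 3 (0.41 log units; beyond the scatter), the only step at this position so far printed as beyond the scatter. In a physicochemical assay for solubility, read by HPLC, in phosphate buffer, with a stated time of 24 h, at pH 6.8 (a lower number here means a less soluble compound, a higher number a more soluble compound), compound 2 gives < 0.15 ug/mL, which is a limit of the assay. In the physicochemical assay compound 3 gives < 0.14 ug/mL, also a limit, so the step for this change cannot be read there.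

The three groups shown on this oxygen contain carbon only. From the compounds shown here alone, how a group carrying an amine or a hydroxyl would read in the Glucose-dependent insulinotropic receptor assay and the physicochemical assay remains open.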